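Working notes: arylsulfonyl for aryl on the ring nitrogen

The source may hold more compounds than are shown below. What is called first, only, known or untested is meant among the compounds shown, and "the series" means these compounds.

Measured so far:
compound 1 `O=C(/C=C/c1ccccc1)c1ccc(N2CCN(c3cccc(Cl)c3)CC2)cc1`: 14.1%
compound 2 `Cc1ccc(N2CCN(c3ccc(C(=O)/C=C/c4ccc(Cl)cc4)cc3)CC2)c(C)c1`: 25.7%
compound 3 `COc1ccc(N2CCN(c3ccc(C(=O)/C=C/c4ccc(Cl)cc4)cc3)CC2)cc1`: 55.1%

In a functional assay on the whole organism (strain Kunming) for inhibition, with Mus musculus as the target, with a stated time of 1 h, at a dose of 40 mg/kg by the oral route (on this read-out higher numbers stand for more inhibition at the one dose given (going by the name of the read-out) and lower numbers for less inhibition), compound 1 stands lowest of the three numbers, beyond the scatter below compound 2 and furthest below compound 3. Among the measured compounds shown here, the only single-place step measured is the one from compound 2 to compound 3, a number 29.4 percentage points higher from compound 2 to compound 3 (beyond the scatter), which swaps one aryl group for another on the same ring nitrogen of the shared core.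

Compound 4 `O=C(/C=C/c1ccccc1)c1ccc(N2CCN(S(=O)(=O)c3ccc(Br)cc3)CC2)cc1` is not yet measured. It differs from compound 1 in one place: (4-bromophenyl)sulfonyl in place of 3-chlorophenyl on an amine nitrogen in a ring. For the measured compounds named here, the step between compound 2 and compound 3 bears only loosely on this, since neither of those aryl groups becomes an arylsulfonyl, and no measured pair shows what a sulfonyl on that nitrogen does. With nothing closer to go on, the expected change in this assay is no step beyond the scatter, or at most a modest one in either direction. For compound 4 the estimate is 20%, with a range from 5% to 45%, meaning an expected step of a number 5.9 percentage points higher from compound 1 to compound 4 (within the scatter).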

Compound 4, a percentage reported as inhibition, in the whole organism at one dose (the size of the read-out at that dose, not a potency): 47.4%
Compound 4: the middle estimate sits 27.4 percentage points below what was measured; measured number outside the range, above it.
By their numbers in this assay, from the lowest: compound 1; then compound 2; then compounds 4 and 3 (each within the scatter of the next).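

In this assay the ring nitrogen of the shared core is not limited to a directly attached aryl group: (4-bromophenyl)sulfonyl in place of 3-chlorophenyl gives a number 33.3 percentage points higher from compound 1 to compound 4 (beyond the scatter) and is a large step. The entering group adds a sulfonyl with 2 hydrogen-bond acceptors and also moves and changes the halogen on the aromatic ring, so this single step cannot divide the gain among those changes. No measurement at hand accounts for the step.

Open, going by these compounds, is whether the sulfonyl link or the halogen carries the step, which a (3-chlorophenyl)sulfonyl group on the same nitrogen would help separate. Also open, on these data alone, is how far the result extends to other links on this nitrogen, such as a benzoyl group or a methanesulfonyl group.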